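Swapping a Cyclopropyl Urea Cap for a Piperazine Chain

The compounds below may be only part of what the source reports. "The series", "measured", "known", "first", "only" and "open" are said of these compounds alone.

Measured in a functional assay on HCT-116 cells (Homo sapiens) for antiproliferative activity, read by MTT assay, with a stated time of 72 h; on this read-out higher numbers stand for weaker inhibition and lower numbers for stronger inhibition:

Compound 1 `COc1ncc(-c2ccc3nc(NC(=O)NC4CC4)sc3c2)cc1NS(=O)(=O)c1ccc(F)cc1` gives 470 nM.
Compound 2 `O=C(Nc1nc2ccc(-c3cnc(Cl)c(NS(=O)(=O)c4ccc(F)cc4)c3)cc2s1)NC1CC1` gives 1750 nM.
Compound 3 `CCN(CC)CCNC(=O)Nc1nc2ccc(-c3cnc(Cl)c(NS(=O)(=O)c4ccc(F)cc4)c3)cc2s1` gives 920 nM.

Compound 1 has the lowest number of the three. Its nearest neighbour is compound 3, and the gap between them lies within the scatter, so the two cannot be ranked; compound 2 sits furthest away, with the step of a 3.7-fold higher number from compound 1 to compound 2 (0.57 log units; beyond the scatter).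

The unmeasured compound 4 `COc1ncc(-c2ccc3nc(NC(=O)NCCN4CCN(C)CC4)sc3c2)cc1NS(=O)(=O)c1ccc(F)cc1` keeps the methoxy of compound 1 and changes only the urea end: 2-(4-methylpiperazin-1-yl)ethyl in place of cyclopropyl on an amide-type nitrogen. For the measured compounds named here, the one measured step that bears on this is a 1.9-fold lower number from compound 2 to compound 3 (0.28 log units; within the scatter), where the same cyclopropyl gave way to a different chain on the same amide-type nitrogen, and the result stayed within the scatter. The step from compound 1 to compound 2 concerns another position and says nothing about the urea end.

On that basis the expected step of a 1.3-fold lower number from compound 1 to compound 4 (0.13 log units; within the scatter) is small, at most a slight lowering, and may be nothing beyond the scatter. Compound 4 is therefore estimated at 350 nM, with a range from 120 nM to 1000 nM.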

Compound 4, half-maximal inhibitory concentration: 540 nM
For compound 4 the middle estimate is 1.5-fold (0.19 log units) below the measured one; measured number inside the range.
By their numbers in this assay, from the lowest: compounds 1, 4, 3 and 2 (each within the scatter of the next, the first and the last beyond it).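

In this assay, replacing the small cyclopropyl of compound 1 with the much larger 2-(4-methylpiperazin-1-yl)ethyl chain gives a 1.1-fold higher number from compound 1 to compound 4 (0.06 log units; within the scatter), so the two compounds cannot be told apart. The earlier chain swap at this amide-type nitrogen was seen only with chloro on the core, whereas this one keeps the methoxy, so among the compounds shown, two different chains in two settings both stay within the scatter of the cyclopropyl compound. No measurement here explains why such a large difference in the chain leaves the result within the scatter.

A simple aminoethyl chain or a carboxylic acid on this nitrogen could still behave differently. From the compounds shown here alone, it also remains open whether the 2-(4-methylpiperazin-1-yl)ethyl chain would give the same result with chloro in place of methoxy.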